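The compounds below may be only part of what the source reports. "The series", "measured", "known", "first", "only" and "open" are said of these compounds alone.

Measured in a functional assay on MCF7 cells (Homo sapiens) for inhibition, read by CCK-8 assay, with a stated time of 48 h; a lower number here means a stronger inhibitor, a higher number a weaker inhibitor:

- Compound 1 `COc1cc(-c2ccnc3cc(-c4ccc(F)cc4)nn23)cc(OC)c1OC`: 1280 nM
- Compound 2 `COc1cc(-c2ccnc3cc(-c4cccc(C#N)c4)nn23)cc(OC)c1OC`: > 10000 nM, a limit
- Compound 3 `COc1cc(-c2ccnc3cc(-c4ccc(C(F)(F)F)cc4)nn23)cc(OC)c1OC`: 2440 nM

Among the compounds with values here, the series holds only two numeric values, and they are not separated: a 1.9-fold higher number from compound 1 to compound 3 (0.28 log units; within the scatter). The remaining value is a limit: an at least 4.0-fold lower number from compound 2 to compound 3 (0.61 log units; beyond the scatter).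

Compound 4 `C=Cc1ccc(-c2cc3nccc(-c4cc(OC)c(OC)c(OC)c4)n3n2)cc1` carries vinyl in place of trifluoromethyl on an aromatic carbon, para to a large group, so that 4-(trifluoromethyl)phenyl becomes 4-vinylphenyl: vinyl in place of trifluoromethyl on an aromatic carbon.

Within the data shown here, the closest precedent is the exchange of fluoro for trifluoromethyl, which stayed small: a 1.9-fold higher number from compound 1 to compound 3 (0.28 log units; within the scatter). The larger step, an at least 7.8-fold higher number from compound 1 to compound 2 (0.89 log units; beyond the scatter), swaps 4-fluorophenyl for 3-cyanophenyl, a different kind of change, and so bears less on this one. In this assay, no step beyond the scatter is therefore expected, and the expected step is a 1.2-fold lower number from compound 3 to compound 4 (0.09 log units; within the scatter). For compound 4 the estimated value is 2000 nM, with an expected range from 700 nM to 6000 nM.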

Compound 4, half-maximal inhibitory concentration: 193 nM
Beside the measured number, compound 4's estimate is 10-fold (1.02 log units) above it; the whole stated range lies above it.
By their numbers in this assay, from the lowest: compound 4; then compounds 1 and 3 (each within the scatter of the next). At a limit, above all of these: compound 2.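

In this assay, the group on the aromatic carbon para to a large group now moves the number well beyond the scatter: vinyl gives a 13-fold lower number from compound 3 to compound 4 (1.10 log units; beyond the scatter) and a 6.6-fold lower number from compound 1 to compound 4 (0.82 log units; beyond the scatter), whereas fluoro and trifluoromethyl did not separate. Of the groups shown at this place, only vinyl brings a double bond outside aromatic rings, and compound 4, which carries it, gives 193 nM. Compound 2 stands at a limit, so an at least 51-fold lower number from compound 2 to compound 4 (1.71 log units; beyond the scatter) is a bound only: the limit of > 10000 nM in this assay, at which 1 of the 4 values shown sits.

Going by these compounds, whether the double bond itself carries the step remains open, as one vinyl compound cannot separate it from the loss of trifluoromethyl or fluoro. Ethyl, ethynyl or methoxy at the same place would test this, and an amine there would extend the comparison.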